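Swapping the Aryl Amide of Compound 1 for a Carbamate

The source may report more compounds than this note shows. Statements on the series, on what has been measured and on what is new or still open speak of the compounds shown alone.

Compound 1 `Cc1cc(C(=O)Nc2c(F)cccc2F)nn1Cc1cc(Cl)ccc1OCc1ccccc1` is the most potent of the three measured compounds in an assay on CHO-K1 cells for displacement of a labelled ligand from prostaglandin E2 receptor EP1 subtype (Homo sapiens) (a lower number here means a stronger inhibitor, a higher number a weaker inhibitor), where compound 1 gives 10 nM. Compound 2 `Cc1cc(NC(=O)C2CCOC2)nn1Cc1cc(Cl)ccc1OCc1ccccc1` gives 39.8 nM, and compound 3 `Cc1cc(NC(=O)OCc2ccccn2)nn1Cc1cc(Cl)ccc1OCc1ccccc1` gives 79.4 nM. Compound 4 `Cc1cc(NC(=O)OCC(C)C)nn1Cc1cc(Cl)ccc1OCc1ccccc1` has not yet been measured; it differs from compound 1 in a single place: (isobutoxycarbonyl)amino in place of (2,6-difluorophenyl)carbamoyl on an aromatic carbon. For the measured compounds named here, two measured steps bear on this change, each replacing the same group on the shared core: a 4.0-fold higher number from compound 1 to compound 2 (0.60 log units; beyond the scatter) and a 7.9-fold higher number from compound 1 to compound 3 (0.90 log units; beyond the scatter). Going by the values given here, of these, the group entering in compound 3 most resembles the one entering in compound 4, so a modest loss of the same order is expected for compound 4, a 5.0-fold higher number from compound 1 to compound 4 (0.70 log units; beyond the scatter). The estimated value of compound 4 in this assay is 50 nM, within a range from 20 nM to 160 nM.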

Compound 4, half-maximal inhibitory concentration: 25.1 nM
The estimate for compound 4 lay 2.0-fold (0.30 log units) above the measured number, within the range that was stated.
By their numbers in this assay, from the lowest: compound 1; then compounds 4, 2 and 3 (each within the scatter of the next, the first and the last beyond it).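

In this assay, a group with no ring can replace (2,6-difluorophenyl)carbamoyl on this aromatic carbon at a modest cost, with a 2.5-fold higher number from compound 1 to compound 4 (0.40 log units; beyond the scatter). The group on the carbamate oxygen also matters, since isopropyl in place of pyridin-2-yl gives a 3.2-fold lower number from compound 3 to compound 4 (0.50 log units; beyond the scatter). Isobutoxy in place of oxolan-3-yl on the carbonyl carbon gives a 1.6-fold lower number from compound 2 to compound 4 (0.20 log units; within the scatter).

No evidence here explains these steps. On these data alone, whether a longer chain or a cyclohexyl group on the carbamate oxygen would bring the number closer to that of compound 1 remains open.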